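The source may hold more compounds than are shown below. What is called first, only, known or untested is meant among the compounds shown, and "the series" means these compounds.

In a functional assay on CHO cells for antagonist activity at prostaglandin E2 receptor EP4 subtype (Homo sapiens), read by calcium flux, with a stated time of 15 min (a lower number here means a stronger inhibitor, a higher number a weaker inhibitor), two compounds have been measured. Compound 2 `C[C@H](NC(=O)c1c(-c2ccccc2)nnn1Cc1ccc(F)cc1)c1ccc(C(=O)O)cc1` gives 330 nM, the lower of the two numbers. Compound 1 `C[C@H](NC(=O)c1c(C(F)(F)F)nnn1Cc1cccc(C(F)(F)F)c1)c1ccc(C(=O)O)cc1` gives 1970 nM, a higher number that lies beyond the scatter of this assay. These two compounds differ from each other in more than one place, so their gap can not be tied to any single group.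

Compound 3 `C[C@H](NC(=O)c1c(-c2ccccc2)nnn1Cc1cccc(C(F)(F)F)c1)c1ccc(C(=O)O)cc1` keeps the core of compound 2 and differs from it in one place: 3-(trifluoromethyl)phenyl in place of 4-fluorophenyl on a saturated chain carbon bound to an aromatic nitrogen. The same benzyl group is already present in compound 1, but compound 1 also carries a different group on the shared core, so the pair of compound 1 and compound 2 gives no clean reading of this one change on its own.

Among the compounds with values here, with no single-change step available to lean on, the step that is expected here is a 1.1-fold lower number from compound 2 to compound 3 (0.04 log units; within the scatter), that is, no shift beyond the scatter in either direction. On this basis compound 3 is expected to give 300 nM in this assay, with a range from 90 nM to 1000 nM.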

Compound 3, half-maximal inhibitory concentration: 23 nM
Compound 3: the middle estimate sits 13-fold (1.12 log units) above what was measured; the measured number lies below the stated range.
By their numbers in this assay, from the lowest: compound 3; then compound 2; then compound 1.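

In this assay, the group on the saturated chain carbon bound to an aromatic nitrogen clearly matters: 3-(trifluoromethyl)phenyl in place of 4-fluorophenyl gives a 14-fold lower number from compound 2 to compound 3 (1.16 log units; beyond the scatter), a step that compound 1 and compound 2 could not isolate. Compound 3 also gives a clean reading of the other place in which those two compounds differ, since phenyl in place of trifluoromethyl on an aromatic carbon, with the 3-(trifluoromethyl)benzyl group kept, gives an 86-fold lower number from compound 1 to compound 3 (1.93 log units; beyond the scatter), so both places in the molecule respond beyond the scatter. Nothing at hand explains why either change has such an effect on the number.

The step from 4-fluorobenzyl to 3-(trifluoromethyl)benzyl changes both the group on the ring and where it stands, so these compounds cannot tell which of the two carries the step, nor whether a chlorine atom or a nitrile on that ring would do the same. Also open, from the compounds shown here alone, is whether the phenyl on the aromatic carbon is special, or whether a methyl group or a pyridine ring there would give a similar number.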